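The compounds below may be only part of what the source reports. "The series", "measured", "known", "first", "only" and "open" are said of these compounds alone.

Measured compounds:
compound 1 `ClCc1ccccc1Cn1cnc2c(Cl)nc(Cl)nc21` gives 350 nM
compound 2 `Nc1nc(Cl)c2ncn(Cc3ccc(CCl)cc3)c2n1` gives 13800 nM
compound 3 `ClCc1ccc(Cn2cnc3c(Cl)nc(Cl)nc32)cc1` gives 17400 nM

In a functional assay on SW-620 cells (Homo sapiens) for cytotoxicity, read by sulforhodamine B assay, with a stated time of 48 h (a higher number here means a weaker inhibitor of growth, a lower number a stronger inhibitor of growth), compound 1 stands lowest of the three numbers. Compound 2 is nearest, and compound 3 furthest, both beyond the scatter, so compound 1 is the strongest inhibitor of growth among the measured set.

The step to the unmeasured compound 4 `Nc1nc(Cl)c2ncn(Cc3ccccc3CCl)c2n1` is amino in place of chloro on an aromatic carbon. Of the measured steps, only one bears on it: the change from compound 2 to compound 3 is the same exchange run the other way, and it gave a 1.3-fold higher number from compound 2 to compound 3 (0.10 log units; within the scatter). On that evidence, swapping chloro for amino at this position left this assay essentially unchanged in the one case where it was tested. Compound 4 carries the amino on the core of compound 1, whose benzyl substitution differs from that of compounds 2 and 3, so the carry-over is not certain.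

He therefore expects no step beyond the scatter, perhaps a slightly lower number, giving a 1.2-fold lower number from compound 1 to compound 4 (0.07 log units; within the scatter) as his estimated step. His estimate for compound 4 in this assay is 300 nM, with a range from 90 nM to 1200 nM.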

Compound 4, concentration for total growth inhibition: 11800 nM
Compound 4: the middle estimate sits 39-fold (1.59 log units) below what was measured; measured number above the stated range.
By their numbers in this assay, from the lowest: compound 1; then compounds 4, 2 and 3 (each within the scatter of the next).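

In this assay, the exchange at the aromatic carbon between two ring nitrogen atoms proves far from neutral on the core of compound 1, where amino in place of chloro gave a 34-fold higher number from compound 1 to compound 4 (1.53 log units; beyond the scatter). In this pair, the chloro is the one difference separating the low number of compound 1 from the much higher number of compound 4, whereas the earlier pair on the other core showed no difference beyond the scatter. The result of this change therefore cannot be carried from one core to the other, since the two steps differ by more than the scatter allows: the same change on two cores in this assay, a 1.3-fold higher number (0.10 log units; within the scatter) from compound 2 to compound 3 and a 34-fold lower number (1.53 log units; beyond the scatter) from compound 4 to compound 1, 43-fold (1.63 log units) apart, beyond the scatter of two such steps.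

The compounds shown leave open whether the low number of compound 1 requires chloro specifically or would also hold with another group at this position, such as a fluoro group, a methoxy group or a methylamino group. They also leave open which feature of the benzyl substitution makes the outcome of the exchange differ between the two cores.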